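The compounds below may be only part of what the source reports. "The series", "measured", "known", "first", "only" and "open" are said of these compounds alone.

Compound 1 `CC(C)CCc1ccc2c(NCCCNCc3ccco3)ccnc2c1` gives 9.47 in a physicochemical assay for acid dissociation.
Compound 2 `c1coc(CNCCCNc2ccnc3cc(-c4cccc5ccccc45)ccc23)c1` gives 9.47 in this assay.
Compound 3 `c1coc(CNCCCNc2ccnc3cc(C4CCCCC4)ccc23)c1` gives 9.47 in this assay.

Compound 3 stands level with compounds 1 and 2 at the digits shown; its nearest neighbour on the numbers is compound 1 and its furthest is compound 2, and both gaps lie within the scatter. The step to compound 4 `N#Cc1ccc(Cc2ccc3c(NCCCNCc4ccco4)ccnc3c2)cc1` is 4-cyanobenzyl in place of cyclohexyl on an aromatic carbon. The three measured steps all swap a group on the same aromatic carbon of the shared core, and each left the value unchanged: no change at the digits printed from compound 1 to compound 2 (within the scatter), no change at the digits printed from compound 1 to compound 3 (within the scatter) and no change at the digits printed from compound 2 to compound 3 (within the scatter). Since every exchange of this kind so far has been flat, the move from cyclohexyl to 4-cyanobenzyl at that carbon is expected to produce no step beyond the scatter, a number 0.02 log units lower from compound 3 to compound 4 (within the scatter). Compound 4 is therefore estimated at 9.45 in this assay, expected to fall between 9.15 and 9.75.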

Compound 4, acid dissociation constant: 9.47
Estimate against measurement, compound 4: 0.02 log units below; measured number inside the range.
By their numbers in this assay, from the lowest: compounds 1, 2, 3 and 4 (each within the scatter of the next).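

In this assay, among these compounds, 4-cyanobenzyl is the first group at this aromatic carbon to bring in nitrogen, a triple bond outside aromatic rings and a hydrogen-bond acceptor, yet the read-out shows no change at the digits printed from compound 3 to compound 4 (within the scatter). The same holds against the other groups, with no change at the digits printed from compound 2 to compound 4 (within the scatter) and, read as 4-cyanophenyl in place of isobutyl on a saturated chain carbon bound to an aromatic carbon, no change at the digits printed from compound 1 to compound 4 (within the scatter). The flat picture at this position thus now reaches beyond groups made of carbon alone, although nothing measured here explains it.

Still open, as far as these compounds go, is whether an amine or a carboxylic acid at this carbon would leave the value level as well. The compounds shown also leave open whether a change elsewhere on the shared core, or a longer chain in the shared side chain, would move it.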